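This account rests on a few compounds, and the source may have more. Where it says the series, first, only, none or still open, it means among the compounds named here.

Measured in a functional assay on SGC-7901 cells (Homo sapiens) for antiproliferative activity, read by MTT assay, with a stated time of 72 h; a lower number here means a stronger inhibitor, a higher number a weaker inhibitor:
- compound 1 `COc1cc(-n2cnc3ccc(-c4ccc(C(C)=O)cc4)cc32)cc(OC)c1OC`: 450 nM
- compound 2 `COc1ccc(-c2ccc3ncn(-c4cc(OC)c(OC)c(OC)c4)c3c2)cc1F`: 430 nM
- compound 3 `COc1cc(-n2cnc3ccc(-c4ccccc4)cc32)cc(OC)c1OC`: 290 nM

Compound 2 stands within the scatter of both other compounds, as shown by a 1.0-fold lower number from compound 1 to compound 2 (0.02 log units; within the scatter) and a 1.5-fold lower number from compound 2 to compound 3 (0.17 log units; within the scatter). Compound 4 `COc1cc(-n2cnc3ccc(-c4cccc(C)c4)cc32)cc(OC)c1OC` carries 3-methylphenyl in place of 3-fluoro-4-methoxyphenyl on an aromatic carbon. Within the data shown here, the closest precedent is compound 3, where phenyl replaces the same group, and that step stayed within the scatter. The step of a 1.6-fold lower number from compound 1 to compound 3 (0.19 log units; within the scatter) did too. No change among these three compounds has gone beyond the scatter, so no step beyond it is expected in this assay. The expected change is a 1.3-fold lower number from compound 2 to compound 4 (0.11 log units; within the scatter). For compound 4 the estimated value is 330 nM, with an expected range of 150 nM to 700 nM.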

Compound 4, half-maximal inhibitory concentration: 1240 nM
Beside the measured number, compound 4's estimate is 3.8-fold (0.57 log units) below it, and the stated range ends below it.
By their numbers in this assay, from the lowest: compounds 3, 2 and 1 (each within the scatter of the next); then compound 4.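

In this assay, among these compounds, methyl in place of hydrogen gives a 4.3-fold higher number from compound 3 to compound 4 (0.63 log units; beyond the scatter), the first change at this position to pass the scatter, so a single small group on the phenyl ring can matter here. 3-Methylphenyl also stands apart from the other two groups, with a 2.9-fold higher number from compound 2 to compound 4 (0.46 log units; beyond the scatter) and a 2.8-fold higher number from compound 1 to compound 4 (0.44 log units; beyond the scatter), although those two groups stayed within the scatter of phenyl. Nothing available explains this difference. Going by these compounds, it remains open whether 4-methylphenyl, 3-methoxyphenyl or 3-aminophenyl would track compound 4 or compound 3. The compounds shown therefore cannot separate the effect of the methyl group from that of its place on the ring.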